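A few compounds are considered here, and "the series" means these few. Any claim that something is new, unique, unknown or untested is made for them only; others in the source may bear on it.

Compound 1 `CC(=O)Oc1c(O)cc2oc(-c3ccccc3)cc(=O)c2c1O`: 61600 nM
Compound 2 `O=c1cc(-c2ccccc2)oc2cc(O)c(OCc3ccccc3)c(O)c12`: 3200 nM

Going by the values given here, in a functional assay on KB 3-1 cells (Homo sapiens) for inhibition, with a stated time of 72 h (a higher number here means a weaker inhibitor, a lower number a stronger inhibitor), compound 2 `O=c1cc(-c2ccccc2)oc2cc(O)c(OCc3ccccc3)c(O)c12` gives 3200 nM, the lowest of the two numbers so far. Compound 3 `O=c1cc(-c2ccccc2)oc2cc(O)c(OCc3ccccc3)c(OCc3ccccc3)c12` differs from it by benzyl in place of hydrogen on an oxygen on an aromatic ring. Among the compounds with values here, one measured step bears on this, the large 19-fold lower number from compound 1 to compound 2 (1.28 log units; beyond the scatter), which also brought in benzyl on such an oxygen. However, that benzyl replaced acetyl, not hydrogen, so this step is a weak guide to the new change and no clear direction can be drawn from it. The expected result is a 1.1-fold lower number from compound 2 to compound 3 (0.03 log units; within the scatter), with no shift beyond the scatter as the likeliest outcome. For compound 3 the estimated value is 3000 nM, with an expected range from 800 nM to 20000 nM.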

Compound 3, half-maximal inhibitory concentration: > 100000 nM
Compound 3: no number, only a limit; the forecaster's own chance of this, stated with the estimate: 15%; middle value at least 33-fold (1.52 log units) from the limit.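

Changing hydroxy to benzyloxy on this oxygen gives an at least 31-fold higher number from compound 2 to compound 3 (1.49 log units; beyond the scatter) in this assay. The earlier step showed only benzyl in place of acetyl, with a lower number, whereas this one shows that adding a further benzyl to compound 2 on this oxygen, in place of hydrogen, goes the opposite way. For compound 3 the result is a limit of the assay, not a number: the limit of > 100000 nM in this assay, at which 1 of the 3 values shown sits.

From the compounds shown here alone, how far compound 3 lies past that limit stays open. So does whether a methyl group or a chain ending in an amine on this oxygen would give a measurable number.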